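The source may report more compounds than this note shows. Statements on the series, on what has been measured and on what is new or still open speak of the compounds shown alone.

Of the compounds shown here, two have been measured in an ADME assay for permeability, using PAMPA, with a stated time of 4 h, at pH 7.4, tested at 100 uM; a lower number here means that the compound crosses the layer more slowly, a higher number that the compound crosses the layer faster. There, compound 1 (`Cc1nc2cc(-c3ccccc3)nn2c(N2CCC(C)(C)CC2)c1C(OC(C)(C)C)C(=O)O`) gives 703 nm/s and compound 2 (`Cc1ccc(-c2cc3nc(C)c(C(OC(C)(C)C)C(=O)O)c(-c4cc(F)c5c(c4C)CCCO5)n3n2)cc1`) gives 492 nm/s, so compound 2 stands within the usual scatter of compound 1, and neither can be ranked above the other. Among the compounds with values here, the two structures differ in more than one place, so no measured pair isolates a single change. Compound 3 (`Cc1nc2cc(-c3ccc(OCc4ccccc4)cc3)nn2c(-c2cc(F)c3c(c2C)CCCO3)c1C(OC(C)(C)C)C(=O)O`) matches compound 2 except at one site: benzyloxy in place of methyl on an aromatic carbon. In words, benzyloxy stands in place of methyl on an aromatic carbon, para to a large group. With no measurement of such a swap available, only a small fall in this assay, close to the scatter, is expected, and the estimated step is a 1.3-fold lower number from compound 2 to compound 3 (0.11 log units; within the scatter). Compound 3 is expected at 380 nm/s, with an estimated range from 130 nm/s to 850 nm/s.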

Compound 3, apparent permeability: 313 nm/s
Estimate against measurement, compound 3: 1.2-fold (0.08 log units) above, within the range that was stated.
By their numbers in this assay, from the lowest: compounds 3, 2 and 1 (each within the scatter of the next, the first and the last beyond it).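

Replacing methyl with benzyloxy on an aromatic carbon, para to a large group, gives a 1.6-fold lower number from compound 2 to compound 3 (0.20 log units; within the scatter) in this assay. Within the data shown here, this is the first single-site comparison in the set, and it shows that this position can carry benzyloxy, with 8 heavy atoms and a six-membered aromatic ring of carbon only, in place of methyl, with 1 heavy atom, without a step that stands beyond the scatter. No measurement shown offers an explanation for this result.

As far as these compounds go, it remains open how the read-out would respond at this position to an amine or a carboxylic acid, both of which differ from benzyloxy and methyl. From the compounds shown here alone, it is also open whether the same swap would give a similar step on a compound with the dimethylpiperidine-bearing shape of compound 1, or with a longer chain such as phenylpropyloxy in place of benzyloxy.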